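Removing One Dichlorobenzyl Ether Group

The source may hold more compounds than are shown below. What is called first, only, known or untested is meant among the compounds shown, and "the series" means these compounds.

Measured compounds:
compound 1 `C=CCc1ccc(OCc2ccccc2)c(-c2ccc(O)c(CC=C)c2)c1`: 22300 nM
compound 2 `C=CCc1ccc(OCc2ccc(Cl)cc2Cl)c(-c2ccc(OCc3ccc(Cl)cc3Cl)c(CC=C)c2)c1`: > 50000 nM
compound 3 `C=CCc1ccc(OCc2ccc(Cl)c(Cl)c2)c(-c2ccc(OCc3ccc(Cl)c(Cl)c3)c(CC=C)c2)c1`: > 50000 nM

Of the compounds shown here, three have been tested in a functional assay on MCF7 cells (Homo sapiens) for inhibition, read by MTT assay, with a stated time of 72 h; on this read-out higher numbers stand for weaker inhibition and lower numbers for stronger inhibition. Compound 1 `C=CCc1ccc(OCc2ccccc2)c(-c2ccc(O)c(CC=C)c2)c1` carries one benzyl ether and one free hydroxy and gives 22300 nM. Compound 2 `C=CCc1ccc(OCc2ccc(Cl)cc2Cl)c(-c2ccc(OCc3ccc(Cl)cc3Cl)c(CC=C)c2)c1` carries two 2,4-dichlorobenzyl ethers, and its value of > 50000 nM is only a limit of the assay, not a number. Compound 3 `C=CCc1ccc(OCc2ccc(Cl)c(Cl)c2)c(-c2ccc(OCc3ccc(Cl)c(Cl)c3)c(CC=C)c2)c1` carries two 3,4-dichlorobenzyl ethers and also reaches only the limit > 50000 nM. Compound 2 therefore stands at the weak end of what is shown: the limit of > 50000 nM in this assay, at which 2 of the 3 values shown sit. It cannot be told apart from compound 3.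

Compound 4 `C=CCc1ccc(O)c(-c2ccc(OCc3ccc(Cl)cc3Cl)c(CC=C)c2)c1` differs from compound 2 in one place: hydrogen in place of 2,4-dichlorobenzyl on an oxygen on an aromatic ring. This leaves one 2,4-dichlorobenzyl ether and one free hydroxy, an arrangement that resembles compound 1, where one benzyl ether and one free hydroxy are present and a measured number was obtained. Among the measured compounds shown here, no measured step links compound 2 to compound 4, so the size of the step can only be estimated.

Because compound 1 gives 22300 nM with one ether and one free hydroxy, compound 4 is expected to land in a similar range, estimated at 25000 nM between 10000 nM and 50000 nM. That would mean an expected step of an at least 2.0-fold lower number from compound 2 to compound 4 (0.30 log units; that floor lies within the scatter) toward stronger inhibition, larger than the usual scatter, though a value at the limit again cannot be ruled out.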

Compound 4, half-maximal inhibitory concentration: 14700 nM
Beside the measured number, compound 4's estimate is 1.7-fold (0.23 log units) above it; low and high end bracket the measured number.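

In this assay, among the compounds shown here, this is the first comparison between two compounds that differ in one place, and it gives a readable result: replacing a 2,4-dichlorobenzyl with hydrogen on an oxygen on an aromatic ring produces an at least 3.4-fold lower number from compound 2 to compound 4 (0.53 log units; beyond the scatter). So one 2,4-dichlorobenzyl ether can go, leaving a hydroxy, and inhibition in these cells does not get weaker; it moves beyond the usual scatter toward stronger inhibition, and compound 4 comes off the limit with a real number. From the compounds shown here alone, the value of compound 2 is only a limit, so the true step could be larger than the one printed, and its full size stays unknown: the limit of > 50000 nM in this assay, at which 2 of the 4 values shown sit.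

The compounds shown leave open whether the gain comes from the free hydroxy itself or simply from losing the 2,4-dichlorobenzyl, which a small methyl ether or a chain ending in an amine or a carboxylic acid on this oxygen could help to separate. Also open, going by these compounds, is what the same change would do on the other oxygen of compound 2, and what would happen if both 2,4-dichlorobenzyl groups were replaced with hydrogen.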